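This account rests on a few compounds, and the source may have more. Where it says the series, first, only, none or still open, it means among the compounds named here.

Of the compounds shown here, three have been measured in an ADME assay on HepG2 cells (Homo sapiens), read by MTT assay, with a stated time of 72 h, in the presence of a further agent that is not named here (a higher number here means a weaker inhibitor, a lower number a stronger inhibitor), and a fourth awaits its number. Compound 1 `O=C(NC1CCCCC1)Oc1ccccc1C(=O)Nc1ccccc1` gives 51500 nM in this assay. Compound 2 `O=C(Nc1ccccc1)Oc1ccccc1C(=O)Nc1ccccc1` gives 26800 nM in this assay. Compound 3 `O=C(Nc1ccccc1)Oc1ccc(Cl)cc1C(=O)Nc1ccc(C(F)(F)F)cc1` gives 2450 nM in this assay, the lowest of the three numbers; the difference between its core and the core of compound 2 is not broken down here. The step from compound 2 to compound 1 is a single change, (cyclohexyl in place of phenyl on an amide-type nitrogen), and it made a 1.9-fold higher number from compound 2 to compound 1 (0.28 log units; within the scatter).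

Compound 4 `O=C(NC1CCCCC1)Oc1ccc(Cl)cc1C(=O)Nc1ccc(C(F)(F)F)cc1` has not yet been measured in this assay. It differs from compound 3 by the same change, (cyclohexyl in place of phenyl on an amide-type nitrogen), on the same kind of nitrogen, with the same neighbour around the place. Among the compounds with values here, the only guide is the earlier step, where the measured pair moved little: the number from compound 2 to compound 1 stayed within the scatter. The step from compound 3 to compound 4 is therefore expected to be similar, about a 1.6-fold higher number from compound 3 to compound 4 (0.21 log units; within the scatter), because a 1.9-fold higher number from compound 2 to compound 1 (0.28 log units; within the scatter) was small. On that basis compound 4 is estimated at 4000 nM, with a likely range from 1500 nM to 10000 nM.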

Compound 4, half-maximal inhibitory concentration: 750 nM
Compound 4: the middle estimate sits 5.3-fold (0.73 log units) above what was measured; the whole stated range lies above it.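

In this assay the change from phenyl to cyclohexyl on the amide-type nitrogen makes a 3.3-fold lower number from compound 3 to compound 4 (0.51 log units; beyond the scatter), a modest step. The effect of this change therefore depends on the core that carries it, at least for the two cores shown here: the same change on two cores in this assay, a 1.9-fold higher number (0.28 log units; within the scatter) from compound 2 to compound 1 and a 3.3-fold lower number (0.51 log units; beyond the scatter) from compound 3 to compound 4, 6.3-fold (0.80 log units) apart, beyond the scatter of two such steps

The step measured on one core could not simply be copied onto the other, and even its direction differed. Within the data shown here, with only two pairs, this does not show which difference between the cores is responsible, nor how the same change would behave on a third core.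

The cores of compound 2 and compound 3 differ by a chloro group and a trifluoromethyl group together, so the compounds shown leave open whether one of these alone would alter the step. Also open, on these data alone, is how a different group on the same nitrogen, such as a longer chain or a ring carrying an amine, would compare with cyclohexyl and phenyl.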